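A Methoxy Group Added to an Unmoved Series

The source may report more compounds than this note shows. Statements on the series, on what has been measured and on what is new or still open speak of the compounds shown alone.

Among the compounds with values here, in a functional assay on A549 cells (Homo sapiens) for antiproliferative activity, read by MTT assay, with a stated time of 48 h (a lower number here means a stronger inhibitor, a higher number a weaker inhibitor), three compounds have numbers so far. Compound 1 `O=[N+]([O-])c1cccc(-c2nn(-c3ccccc3)cc2C(Nc2nc3ccccc3s2)c2c(O)ccc3ccccc23)c1` gives 32000 nM, compound 2 `Cc1ccc(-c2nn(-c3ccccc3)cc2C(Nc2nc3cc(C)c(C)cc3s2)c2c(O)ccc3ccccc23)cc1` gives 31200 nM, and compound 3 `Oc1ccc2ccccc2c1C(Nc1nc2ccccc2s1)c1cn(-c2ccccc2)nc1-c1ccccc1` gives 36200 nM. Compound 3 therefore stands within the scatter of both others, and the three values cannot be ranked.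

Compound 4 `COc1cccc(-c2nn(-c3ccccc3)cc2C(Nc2nc3ccccc3s2)c2c(O)ccc3ccccc23)c1` differs from compound 3 in one place: methoxy in place of hydrogen on an aromatic carbon. This is methoxy in place of hydrogen on an aromatic carbon, meta to a large group, so that phenyl becomes 3-methoxyphenyl.

Within the data shown here, one measured step bears directly on this change. Compound 1 and compound 3 differ on the same aromatic carbon, and a 1.1-fold higher number from compound 1 to compound 3 (0.05 log units; within the scatter) stays within the scatter, with hydrogen in place of nitro. Among the measured compounds shown here, compound 2 differs from compound 3 in more than one place, so it offers no single step. Even so, compound 2 gives 31200 nM, which lies in the same range. For the measured compounds named here, no compound with methoxy has been measured yet, so this evidence is thin. No step beyond the scatter is expected, and no firm direction can be given. The estimate amounts to a 1.1-fold lower number from compound 3 to compound 4 (0.05 log units; within the scatter), which is expected to stay within the scatter. For compound 4, the estimated value is 32000 nM, with an expected range from 16000 nM to 60000 nM.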

Compound 4, half-maximal inhibitory concentration: 24800 nM
For compound 4 the middle estimate is 1.3-fold (0.11 log units) above the measured one, within the range that was stated.
By their numbers in this assay, from the lowest: compounds 4, 2, 1 and 3 (each within the scatter of the next).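

In this assay this aromatic carbon has now been read with three groups, hydrogen, nitro and methoxy, and methoxy is the new one: the change from phenyl to 3-methoxyphenyl gives a 1.5-fold lower number from compound 3 to compound 4 (0.16 log units; within the scatter) and the exchange of nitro for methoxy on the same carbon gives a 1.3-fold lower number from compound 1 to compound 4 (0.11 log units; within the scatter). Both steps lie within the scatter, as does the earlier step between compound 1 and compound 3, so the three groups cannot be told apart at this position, and a group with oxygen and carbon joins the other two without separating from them. Nothing available explains these small steps or ties them to any feature of methoxy.

The compounds shown leave open whether any group on this carbon can take the number beyond the scatter, for instance an amine, a carboxylic acid or a longer chain such as butoxy. They also leave open whether methoxy would read the same on another carbon of that phenyl ring.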